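Shrinking the Amide Ring: From Pyrrolidine to Azetidine

The compounds below may be only part of what the source reports. "The series", "measured", "known", "first", "only" and "open" are said of these compounds alone.

Three measured compounds share one core and differ only in the group on the aromatic ring. Compound 1 `CC(C)OC(=O)N1CCC2(CC1)CC(CCCOc1ccc(S(C)(=O)=O)c(F)c1)C2` carries a methylsulfonyl there; in a physicochemical assay for solubility, read by HPLC, in phosphate buffer, with a stated time of 24 h, at pH 6.8 (a lower number here means a less soluble compound, a higher number a more soluble compound), compound 1 gives only a limit, < 0.16 ug/mL. Compound 2 `CC(C)OC(=O)N1CCC2(CC1)CC(CCCOc1ccc(C(=O)NC3CC3)c(F)c1)C2` carries a cyclopropylcarbamoyl, and in this assay compound 2 gives 0.21 ug/mL. Compound 3 `CC(C)OC(=O)N1CCC2(CC1)CC(CCCOc1ccc(C(=O)N3CCCC3)c(F)c1)C2` carries a (pyrrolidin-1-yl)carbonyl, and in this assay compound 3 gives 3.85 ug/mL, the highest of the numbers shown. The step of an 18-fold higher number from compound 2 to compound 3 (1.26 log units; beyond the scatter) is large, and so is an at least 24-fold higher number from compound 1 to compound 3 (1.38 log units; beyond the scatter), while an at least 1.3-fold higher number from compound 1 to compound 2 (0.11 log units; that floor lies within the scatter) rests on a limit (the limit of < 0.16 ug/mL in this assay, at which 1 of the 3 values shown sits). Compound 4 `CC(C)OC(=O)N1CCC2(CC1)CC(CCCOc1ccc(C(=O)N3CCC3)c(F)c1)C2` has not yet been measured; it differs from compound 3 by azetidin-1-yl in place of pyrrolidin-1-yl on a carbonyl carbon. For the measured compounds named here, none of the measured steps changes the size of the ring-shaped group on the carbonyl carbon, so they offer no direct guide. Both rings are small and of the same kind, so compound 4 is expected to stay near compound 3, with a 1.3-fold higher number from compound 3 to compound 4 (0.11 log units; within the scatter) lying within the scatter. The estimated value for compound 4 is 5 ug/mL, between 1.5 ug/mL and 15 ug/mL.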

Compound 4, solubility: 3.43 ug/mL
Estimate against measurement, compound 4: 1.5-fold (0.16 log units) above, and the stated range covers the measured number.
By their numbers in this assay, from the lowest: compound 2; then compounds 4 and 3 (each within the scatter of the next). At a limit, below all of these: compound 1.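

In this assay, the four-membered azetidin-1-yl and the five-membered pyrrolidin-1-yl on this carbonyl carbon cannot be told apart, with a 1.1-fold lower number from compound 3 to compound 4 (0.05 log units; within the scatter). The large step away from cyclopropylamino also appears with the smaller ring, with a 16-fold higher number from compound 2 to compound 4 (1.21 log units; beyond the scatter), so among these compounds it is not confined to the five-membered ring. Against the methylsulfonyl of compound 1, whose value is a limit, the step reads an at least 21-fold higher number from compound 1 to compound 4 (1.33 log units; beyond the scatter), and this gives only a floor: the limit of < 0.16 ug/mL in this assay, at which 1 of the 4 values shown sits.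

Going by these compounds, a six-membered piperidin-1-yl ring, a morpholin-4-yl ring with its second hetero atom, and an open-chain dimethylamino group on the same carbonyl carbon remain untested here. The compounds shown also cannot say whether the amide hydrogen, present in compound 2 and absent from compounds 3 and 4, accounts for the large steps.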